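The compounds below may be only part of what the source reports. "The series", "measured", "known", "first", "only" and "open" are said of these compounds alone.

In a functional assay on HepG2 cells (Homo sapiens) for inhibition, read by MTT assay, with a stated time of 48 h (on this read-out higher numbers stand for weaker inhibition and lower numbers for stronger inhibition), two compounds have been measured so far. Compound 1 `C[Se]c1ccc(N(C)c2nc(C3CC3)nc3ccccc23)cc1` gives 32 nM. Compound 2 `COc1ccc(N(C)c2nc(C)nc3ccccc23)cc1C(=O)OCCC[Se]C#N` gives 340 nM, the higher of the two numbers and beyond the usual scatter of compound 1, although these two compounds differ in more than one place. Compound 3 `COc1ccc(N(C)c2nc(C)nc3ccccc23)cc1OCCCC[Se]C#N` departs from compound 2 in a single place: a group of 8 heavy atoms (5 carbon, 1 nitrogen, 1 oxygen, 1 selenium; no ring) in place of a group of 9 heavy atoms (5 carbon, 1 nitrogen, 2 oxygen, 1 selenium; no ring), on an aromatic carbon. The change lies on an aromatic carbon, ortho to a methoxy group and meta to a large group. Going by the values given here, no measured pair shows this change, so the data set no size for it. The expectation in this assay is therefore no shift beyond the scatter, in either direction. The estimated step of a 1.4-fold lower number from compound 2 to compound 3 (0.13 log units; within the scatter) is expected to stay within that scatter. For compound 3, the expected value is 250 nM, with an estimated range of 80 nM to 900 nM.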

Compound 3, half-maximal inhibitory concentration: 6460 nM
Estimate against measurement, compound 3: 26-fold (1.41 log units) below; measured number outside the range, above it.
By their numbers in this assay, from the lowest: compound 1; then compound 2; then compound 3.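

In this assay, the aromatic carbon ortho to a methoxy group proves sensitive to the group it carries: the group of 8 heavy atoms in place of the group of 9 heavy atoms gives a 19-fold higher number from compound 2 to compound 3 (1.28 log units; beyond the scatter), although the two groups differ only modestly in their counts. The group of 9 heavy atoms has 1 double bond and 3 hydrogen-bond acceptors, against no double bond and 2 hydrogen-bond acceptors in the group of 8 heavy atoms, so small differences in this group can go with a large step. Nothing measured here accounts for the size of this step.

A single pair cannot show which part of the change carries the step. An amide link or a longer chain at this aromatic carbon could place its value nearer either compound 2 or compound 3.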